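Chloropropyl for hydroxyphenyl on the triazole: compound 4

A few compounds are considered here, and "the series" means these few. Any claim that something is new, unique, unknown or untested is made for them only; others in the source may bear on it.

Measured compounds:
compound 1 `O=C1O[C@H]([C@@H](O)Cn2cc(-c3cc(C(F)(F)F)cc(C(F)(F)F)c3)nn2)C(OCc2ccccc2)=C1OCc1ccccc1` 35500 nM
compound 2 `O=C1O/C(=C\Cn2cc(-c3cc(F)cc(F)c3)nn2)C(OCc2ccccc2)=C1OCc1ccccc1` 17700 nM
compound 3 `O=C1O[C@H]([C@@H](O)Cn2cc(-c3cccc(O)c3)nn2)C(OCc2ccccc2)=C1OCc1ccccc1` 39300 nM

All three compounds share a core and were tested in a functional assay on HeLa cells (Homo sapiens) for antiproliferative activity, read by MTT assay, with a stated time of 72 h; a lower number here means a stronger inhibitor, a higher number a weaker inhibitor. Compound 3 gives the highest number of the three. Compound 1 gives 35500 nM, which stands within the scatter of compound 3, so no order between the two can be read. Compound 2 gives 17700 nM, a lower number than compound 3 and beyond the scatter, but compound 2 differs from compound 3 in more than one place, so this gap is only noted, not assigned.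

Compound 4 `O=C1O[C@H]([C@@H](O)Cn2cc(CCCCl)nn2)C(OCc2ccccc2)=C1OCc1ccccc1` differs from compound 3 as follows: 3-chloropropyl in place of 3-hydroxyphenyl on an aromatic carbon

Among the measured compounds shown here, no step between measured compounds isolates such a change, so nothing tells how much the 3-hydroxyphenyl group contributes. With all three measured values in a narrow, weak range, the expected step of a 1.1-fold higher number from compound 3 to compound 4 (0.03 log units; within the scatter) is none beyond the scatter, with a slight lean toward a higher number. Compound 4 is estimated at 42000 nM, with a range from 15000 nM to 100000 nM.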

Compound 4, half-maximal inhibitory concentration: 36700 nM
Beside the measured number, compound 4's estimate is 1.1-fold (0.06 log units) above it, and the stated range covers the measured number.
By their numbers in this assay, from the lowest: compounds 2, 1, 4 and 3 (each within the scatter of the next, the first and the last beyond it).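

In this assay, among the compounds shown here, 3-chloropropyl in place of 3-hydroxyphenyl on the aromatic carbon gives a 1.1-fold lower number from compound 3 to compound 4 (0.03 log units; within the scatter), the first step that isolates a change at this position. The two compounds cannot be ordered, so at this weak level of activity the position accepts an open chain without the six-membered aromatic ring or the hydrogen-bond donor and acceptor of 3-hydroxyphenyl, and neither feature is shown to matter here. Nothing measured here accounts for this result.

From the compounds shown here alone, whether an amine or a carboxylic acid at the end of the propyl chain, or a longer chain, would give a step beyond the scatter stays open. Also open, going by these compounds, is whether 3-chloropropyl behaves the same way on the core of compound 2.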